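A Single Stereo Form at the Clearance Limit

The source may report more compounds than this note shows. Statements on the series, on what has been measured and on what is new or still open speak of the compounds shown alone.

Of the compounds shown here, three have been measured so far in an ADME assay (liver) for metabolic stability, with Liver microsome (Rattus norvegicus) as the target, using microsomes and NADPH, with a stated time of 30 min, at 37 degrees C, tested at 1 uM; a lower number here means slower removal, a higher number faster removal of the compound. Compound 1 (`Nc1ccc(S(=O)(=O)c2ccc(-c3ccc(C(O)(C(F)(F)F)C(F)(F)F)cn3)cc2)cn1`) gives < 14 mL.min-1.g-1, which is a limit of the assay and not a number. Going by the values given here, compound 2 (`CC(O)(c1ccc(-c2ccc(S(=O)(=O)c3ccc(N)nc3)nc2Nc2ccccn2)nc1)C(F)(F)F`) gives 130 mL.min-1.g-1, the only true number among the three. Compound 3 (`CC(O)(c1ccc(-c2ncc(S(=O)(=O)c3ccc(N)nc3)s2)c(Cl)c1)C(F)(F)F`) gives < 14 mL.min-1.g-1, again a limit and not a number. Compound 3 therefore stands at the limit of < 14 mL.min-1.g-1 in this assay, at which 2 of the 3 values shown sit. Among the compounds with values here, no measured pair in this small set differs in one place only, so the data offer no direct precedent for the next step.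

That step leads to compound 4 (`C[C@](O)(c1ccc(-c2ncc(S(=O)(=O)c3ccc(N)nc3)s2)c(Cl)c1)C(F)(F)F`). The structural change is a matter of configuration alone: the two compounds have the same atoms and bonds; at least one stereo element is drawn with a configuration in one of them and without one in the other: 1 of 1 stereo elements differ; a stereocentre at a saturated chain carbon is drawn without a configuration in compound 3 and S in compound 4. No atom or bond is altered, and compound 4 is drawn as the S form of the stereocentre left undefined in compound 3. In this assay, the expectation therefore rests on compound 3 and its reading of < 14 mL.min-1.g-1. The expected step that the limit leaves unreadable from compound 3 to compound 4 is none beyond the scatter, in neither direction, and the assay may again report only a limit. For compound 4, the estimated intrinsic clearance in microsomes is 13 mL.min-1.g-1, within an expected range of 7 mL.min-1.g-1 to 28 mL.min-1.g-1.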

Compound 4, intrinsic clearance in microsomes: < 14 mL.min-1.g-1
Compound 4: a limit, no number; the forecaster's own chance of this, stated with the estimate: 70%; the middle value is on the limit's open side.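

Compound 3 and compound 4 both read as limits of the assay and not as numbers, so no step can be read between them: the limit of < 14 mL.min-1.g-1 in this assay, at which 3 of the 4 values shown sit.

The compounds shown leave open whether the configuration at this stereocentre has any bearing on intrinsic clearance in microsomes, as no number stands on either side of the change.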